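Lengthening the alkenyl chain of compound 3

A few compounds are considered here, and "the series" means these few. Any claim that something is new, unique, unknown or untested is made for them only; others in the source may bear on it.

- Compound 1 `C=CCCCCOc1ccccc1-c1cnc(OCCCCC=C)n1C`: 7000 nM
- Compound 2 `CCCCCCOc1ncc(-c2ccccc2OC)n1C`: 37000 nM
- Compound 3 `C=CCCOc1ncc(-c2ccccc2OC)n1C`: 22000 nM

All three values come from a functional assay on A549 cells (Homo sapiens) for inhibition, read by colorimetric assay and MTT assay, with a stated time of 72 h; a lower number here means a stronger inhibitor, a higher number a weaker inhibitor. Compound 3 cannot be told apart from compound 2 in this test, as the two lie within the usual scatter of repeated measurements. Compound 1 has a lower number than compound 3, and that gap lies beyond the scatter.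

The next compound is compound 4 `C=CCCCCOc1ncc(-c2ccccc2OC)n1C`, which has a longer chain than compound 3. The change is but-3-en-1-yl in place of vinyl on a saturated chain carbon, two bonds along the chain from an oxygen on an aromatic ring. Cut one bond further out, this reads (but-3-en-1-yl)oxy to (hex-5-en-1-yl)oxy.

Among the measured compounds shown here, only one measured step changes the group at this place: a 1.7-fold lower number from compound 2 to compound 3 (0.23 log units; within the scatter), where vinyl replaced butyl. That step stayed within the scatter, so a similar chain change in this assay gives no reason to expect a large move in either direction. Compound 1 differs from compound 3 in more than one place, so it offers no direct guide.

The expected result is a 1.1-fold higher number from compound 3 to compound 4 (0.06 log units; within the scatter), with no shift beyond the scatter. For compound 4 the estimate is 25000 nM, with an expected range from 11000 nM to 50000 nM.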

Compound 4, half-maximal inhibitory concentration: 5000 nM
Compound 4: middle estimate off by 5.0-fold (0.70 log units), on the high side; the measured number lies below the stated range.
By their numbers in this assay, from the lowest: compounds 4 and 1 (each within the scatter of the next); then compounds 3 and 2 (each within the scatter of the next).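

Among the compounds shown here, the longer chain matters in this assay: with but-3-en-1-yl in place of vinyl, which turns (but-3-en-1-yl)oxy into (hex-5-en-1-yl)oxy, the result is a shift beyond the scatter (a 4.4-fold lower number from compound 3 to compound 4 (0.64 log units; beyond the scatter)), whereas the one earlier step at this position stayed within it. The double bond also counts at this chain length, as vinyl in place of ethyl, on a saturated chain carbon four bonds along the chain from an oxygen on an aromatic ring, gives a second shift beyond the scatter (a 7.4-fold lower number from compound 2 to compound 4 (0.87 log units; beyond the scatter)). Compound 1 and compound 4 cannot be told apart (a 1.4-fold lower number from compound 1 to compound 4 (0.15 log units; within the scatter)), so hydrogen in place of pent-4-en-1-yl, on a saturated chain carbon bound to an oxygen on an aromatic ring, makes no clear difference in this test.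

No measurement shown offers a reason for these shifts. From the compounds shown here alone, it remains open whether a longer alkenyl chain would lower the number further, or whether a chain ending in an amine or a carboxylic acid could take the place of the double bond.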